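From 3-bromophenyl to 2-bromophenyl: a small structural swap

The compounds below may be only part of what the source reports. "The series", "measured", "known", "first", "only" and "open" are said of these compounds alone.

Of the compounds shown here, two with a shared core have been measured so far. In an ADME assay on SH-SY5Y cells (Homo sapiens) for cytotoxicity, read by MTT assay, with a stated time of 72 h (a lower number here means a stronger inhibitor, a higher number a weaker inhibitor), compound 1 `O=C(CN1CCN(C(=O)c2ccc(F)cc2)CC1)N1CCN(CCCc2c[nH]c3ccc(F)cc23)CC1` gives 121000 nM, and compound 2 `O=C(CN1CCN(C(=O)c2cccc(Br)c2)CC1)N1CCN(CCCc2c[nH]c3ccc(F)cc23)CC1` gives 71600 nM. Compound 2 holds the lower of these two numbers, but the gap lies within the scatter of repeated measurements, so the pair cannot truly be ranked.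

Compound 3 `O=C(CN1CCN(C(=O)c2ccccc2Br)CC1)N1CCN(CCCc2c[nH]c3ccc(F)cc23)CC1` has not yet been measured and differs from compound 2 in one place: 2-bromophenyl in place of 3-bromophenyl on a carbonyl carbon. Here 2-bromophenyl stands in place of 3-bromophenyl on a carbonyl carbon, with the same atoms joined differently.

Going by the values given here, only one measured step bears on this change. In a 1.7-fold lower number from compound 1 to compound 2 (0.23 log units; within the scatter), 3-bromophenyl replaced 4-fluorophenyl on a carbonyl carbon, and that step stayed within the scatter. Among the compounds with values here, no measured compound carries 2-bromophenyl, so this guide is thin. A shift beyond the scatter in this assay is therefore not expected, and the estimated step is a 1.1-fold higher number from compound 2 to compound 3 (0.05 log units; within the scatter). For compound 3 the expected value is 80000 nM, with an estimated range of 35000 nM to 160000 nM.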

Compound 3, half-maximal inhibitory concentration: 79100 nM
Compound 3: middle estimate off by 1.0-fold (0.00 log units), on the high side, and the stated range covers the measured number.
By their numbers in this assay, from the lowest: compounds 2, 3 and 1 (each within the scatter of the next).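

In this assay, going by these compounds alone, 2-bromophenyl in place of 3-bromophenyl on the carbonyl carbon gives a 1.1-fold higher number from compound 2 to compound 3 (0.04 log units; within the scatter), the first comparison here of two groups made of the same atoms joined differently, and the change does not separate the two compounds. The other new comparison, 2-bromophenyl in place of 4-fluorophenyl, gives a 1.5-fold lower number from compound 1 to compound 3 (0.18 log units; within the scatter), so all three pairs among compounds 1, 2 and 3 now lie within the scatter and the three cannot be ranked, though this holds only for these three groups on this carbonyl carbon. Nothing available gives a measured reason for these small steps, or for how any of the three groups behaves in these cells.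

As far as these compounds go, all three groups at this place are phenyl rings carrying a single fluorine or bromine, so it remains open whether a phenyl ring bearing an amine or a carboxylic acid, or a saturated ring such as cyclohexyl, would stay within the scatter. Also open, from the compounds shown here alone, is whether 2-fluorophenyl or 3-fluorophenyl would read the same way, and whether the other parts of the shared core matter more for this read-out than this group does.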